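The compounds below may be only part of what the source reports. "The series", "measured", "known", "first", "only" and "open" are said of these compounds alone.

Working notes on the series. In an ADME assay on L02 cells (Homo sapiens) for inhibition, read by MTT assay, with a stated time of 72 h (on this read-out higher numbers stand for weaker inhibition and lower numbers for stronger inhibition), compound 1 `C=CC(=O)Nc1cccc(Oc2nc(Nc3cccc(OC)c3)nc3ccsc23)c1` gives 30300 nM. Compound 2 `C/C=C/C(=O)Nc1cccc(Oc2nc(Nc3cccc(OC)c3)nc3ccsc23)c1` gives 46000 nM in this assay, so the step of a 1.5-fold higher number from compound 1 to compound 2 (0.18 log units; within the scatter) is within the scatter. Compound 3 `C=CC(=O)Nc1cccc(Oc2nc(Nc3cccc(C#N)c3)nc3ccsc23)c1` returns only a limit of the assay in this assay, > 50000 nM. Compound 3 thus stands at the limit of > 50000 nM in this assay, at which 1 of the 3 values shown sits. The step of an at least 1.6-fold higher number from compound 1 to compound 3 (0.21 log units; that floor lies within the scatter) consequently has only a floor, and that floor is within the scatter.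

Compound 4 `C/C=C/C(=O)Nc1cccc(Oc2nc(Nc3cccc(C#N)c3)nc3ccsc23)c1` is not yet measured. The change from compound 3 to compound 4 is prop-1-en-1-yl in place of vinyl on a carbonyl carbon. For the measured compounds named here, the one measured step that bears on this change is a 1.5-fold higher number from compound 1 to compound 2 (0.18 log units; within the scatter), the same exchange carried out on the methoxy-bearing pair, and it stayed within the scatter. No step beyond the scatter is therefore expected in this assay for compound 4. The expected step that the limit leaves unreadable from compound 3 to compound 4 is within the scatter. Compound 4 is estimated at 65000 nM in this assay. The estimate for compound 4 is expected to fall between 30000 nM and 140000 nM. Since compound 3 already sits at the limit, compound 4 is expected most likely to return only a limit as well.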

Compound 4, half-maximal inhibitory concentration: 47900 nM
The estimate for compound 4 lay 1.4-fold (0.13 log units) above the measured number; low and high end bracket the measured number.
By their numbers in this assay, from the lowest: compounds 1, 2 and 4 (each within the scatter of the next). At a limit, above all of these: compound 3.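

In this assay, cyano in place of methoxy on an aromatic carbon now has one complete reading, a 1.0-fold higher number from compound 2 to compound 4 (0.02 log units; within the scatter), with prop-1-en-1-yl on the carbonyl carbon in both compounds. Compound 3 remains a limit of the assay, > 50000 nM. Prop-1-en-1-yl in place of vinyl on a carbonyl carbon gives an at least 1.0-fold lower number from compound 3 to compound 4 (0.01 log units; that floor lies within the scatter) and so touches this limit. The steps that touch this limit cannot be read as sizes, so the vinyl and prop-1-en-1-yl pairs cannot be shown to agree or differ: the same change on two cores in this assay, an at least 1.6-fold higher number (0.21 log units; that floor lies within the scatter) from compound 1 to compound 3 and a 1.0-fold higher number (0.02 log units; within the scatter) from compound 2 to compound 4; the limit leaves it open whether they differ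

On these data alone, no readable step in this assay goes beyond the scatter, so it remains open whether any change at these two places moves the number by more. A longer chain ending in an amine in place of prop-1-en-1-yl, or a carboxylic acid in place of cyano, remains untested among the compounds shown.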